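This account rests on a few compounds, and the source may have more. Where it says the series, first, only, none or still open, it means among the compounds named here.

Measured so far:
Compound 1, `O=C(N/N=C/c1ccc(F)cc1)c1cccnc1Nc1cccc(C(F)(F)F)c1`, gives 41.2% in a functional assay on the whole organism (strain Wistar) for inhibition, with Rattus norvegicus as the target, read by paw edema, with a stated time of 2 h, at a dose of 10 mg/kg by the intraperitoneal route; a higher number here means more inhibition at the dose given (going by the name of the read-out), a lower number less inhibition.
Compound 2, `COc1cccc(/C=N/NC(=O)c2cccnc2Nc2cccc(C(F)(F)F)c2)c1`, gives 49.7% in this assay.

Compound 2 holds the higher of the two numbers, yet the step of a number 8.5 percentage points higher from compound 1 to compound 2 (within the scatter) lies within the usual scatter, so the two compounds cannot be told apart on these data. Compound 3, `O=C(N/N=C/c1cccnc1)c1cccnc1Nc1cccc(C(F)(F)F)c1`, changes compound 2 in one place: pyridin-3-yl in place of 3-methoxyphenyl on a carbon with a double bond to nitrogen. Among the compounds with values here, the only measured step, which also swapped the group on this carbon with a double bond to nitrogen, gave a change within the scatter. Within the data shown here, there is no measured step in which a pyridine ring replaces a carbon-only ring, so the expectation rests on that single step alone. From it, compound 3 is expected to show no change beyond the scatter, an estimated step of a number 6.7 percentage points lower from compound 2 to compound 3 (within the scatter). Compound 3 is therefore estimated at 43% in this assay, with a range from 26% to 60%.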

Compound 3, a percentage reported as inhibition, in the whole organism at one dose (the size of the read-out at that dose, not a potency): 62.4%
Estimate against measurement, compound 3: 19.4 percentage points below; measured number outside the range, above it.
By their numbers in this assay, from the lowest: compounds 1 and 2 (each within the scatter of the next); then compound 3.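

At the carbon with a double bond to nitrogen, the group can change the number in this assay beyond the scatter: pyridin-3-yl gives a number 12.7 percentage points higher from compound 2 to compound 3 (beyond the scatter) and also a number 21.2 percentage points higher from compound 1 to compound 3 (beyond the scatter). The earlier swap between two carbon-only rings did not show this, so pyridin-3-yl stands apart from both 3-methoxyphenyl and 4-fluorophenyl, which remain within the scatter of each other. Nothing available here accounts for this rise.

The compounds shown leave open whether the ring nitrogen itself matters or its place in the ring, as pyridin-3-yl is the only ring here with a hetero atom. They also leave open how a pyridin-4-yl ring, or a carbon-only ring carrying an amine or a carboxylic acid, would compare at this position.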